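The compounds below may be only part of what the source reports. "The series", "measured", "known", "first", "only" and "open" are said of these compounds alone.

Of the compounds shown here, three have so far been measured in a functional assay on the whole organism (B cells) with Mus musculus as the target (on this read-out higher numbers stand for larger maximal responses and lower numbers for smaller maximal responses), and the question is how a fourth will behave. Compound 1 `Nc1nc(O)c2c(n1)n(C1OC(CO)[C@@H](O)[C@H]1O)c(=O)n2C/C=C/c1ccccc1` holds the middle place among them. In this assay compound 1 reaches 73%. Compound 2 `CCCn1c(=O)n(C2CCC(COC(C)=O)O2)c2nc(NC(C)=O)nc(O)c21` stands higher, beyond the usual scatter; in this assay compound 2 reaches 100%. Compound 3 `C=CCn1c(=O)n([C@@H]2O[C@H](CO)[C@H]3OC(C)(CCC(=O)OCC)O[C@H]32)c2nc(N)nc(O)c21` stands lower, again beyond the scatter; in this assay compound 3 reaches 44%.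

Compound 4 `Nc1nc(O)c2c(n1)n(C1OC(CO)[C@@H](O)[C@H]1O)c(=O)n2Cc1ccccc1` differs from compound 1 in a single spot: phenyl in place of 2-phenylethenyl on a saturated chain carbon bound to an aromatic nitrogen. For the measured compounds named here, no measured pair shows this same change, so there is no direct precedent for its effect on the maximal response, and compounds 2 and 3 differ from compound 1 in several places at once, which makes their values of little help here.

Given that, only a modest shift is expected, and if anything a slightly smaller response; the step of a number 8 percentage points lower from compound 1 to compound 4 (within the scatter) is estimated to stay near the edge of the scatter. Compound 4 is therefore expected to give 65%, with a likely range from 45% to 90%.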

Compound 4, largest response reached (reported as maximal response), in percent of the reference or control that the assay uses: 110%
Beside the measured number, compound 4's estimate is 45 percentage points below it; measured number outside the range, above it.
By their numbers in this assay, from the lowest: compound 3; then compound 1; then compounds 2 and 4 (each within the scatter of the next).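

Swapping 3-phenylprop-2-en-1-yl for benzyl on the aromatic nitrogen gives a number 37 percentage points higher from compound 1 to compound 4 (beyond the scatter) in this assay and shows that this position is sensitive: a change that keeps the benzene ring but loses the double bond outside it and goes from 8 heavy atoms to 6 can raise the maximal response well beyond the scatter. The earlier compounds shown here could not show this, as none of them differs from compound 1 in one place only. Nothing given here explains why the smaller group gives the larger response.

The compounds shown leave open whether the gain follows from losing the double bond or from shortening the chain, a question that a saturated 3-phenylpropyl group would help to separate. On these data alone, it also remains open how the response would change with a group on the benzene ring itself, such as an amine or a carboxylic acid.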